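Two Thiophene Isomers and a Sparse Cytotoxicity Record

The source may report more compounds than this note shows. Statements on the series, on what has been measured and on what is new or still open speak of the compounds shown alone.

The cytotoxicity record for this series is thin. In an ADME assay on BJ cells (Homo sapiens) for cytotoxicity, read by MTT assay, with a stated time of 72 h (on this read-out lower numbers stand for higher toxicity in this test and higher numbers for lower toxicity in this test), compound 1 (`CCCCCCCCCCCCCCCCCCOP(=O)(O)OC[C@H]1O[C@@H](n2ccc3c(-c4ccco4)ncnc32)[C@H](O)[C@@H]1O`) gives > 50000 nM as a limit of the assay and not as a number. For compound 2 (`CCCCCCCCCCCCCCCCCCOP(=O)(O)OC[C@H]1O[C@@H](n2ccc3c(-c4cccs4)ncnc32)[C@H](O)[C@@H]1O`) the result in this assay reads "not determined" (no result reported) so this compound has no place on the scale, and compound 1 is the only reference point. Among the compounds with values here, compound 3 (`CCCCCCCCCCCCCCCCCCOP(=O)(O)OC[C@H]1O[C@@H](n2ccc3c(-c4ccsc4)ncnc32)[C@H](O)[C@@H]1O`) has the same atoms as compound 2, joined differently, with thiophen-3-yl in place of thiophen-2-yl on an aromatic carbon as the only change. No step beyond the usual scatter is expected from this swap in this assay and no direction is favoured. That expectation leans on compound 1 at > 50000 nM which is again only a limit. For compound 3 the expected value is 50000 nM with an estimated range from 25000 nM to 100000 nM in this test.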

Compound 3, half-maximal cytotoxic concentration: > 50000 nM
Compound 3: only a limit was reported; the forecaster's own chance of this, stated with the estimate: 75%; the middle value sits exactly at the limit.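

No step can be read from compound 1 to compound 3, because both results are limits of the assay and not numbers: the limit of > 50000 nM in this assay, at which 2 of the 3 values shown sit.

The compounds shown leave open whether furan-2-yl and thiophen-3-yl differ at all in this test, and where compound 2 stands.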